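Trifluoromethyl for isopropoxy on the benzoyl ring

The source may hold more compounds than are shown below. What is called first, only, known or untested is meant among the compounds shown, and "the series" means these compounds.

Measured compounds:
Compound 1, `Cc1c(C(=O)c2ccc(Oc3ccccc3)cc2)oc2cc(-c3ccccc3)cc(O)c12`: > 4 ug/mL
Compound 2, `Cc1c(C(=O)c2cccc(OC(C)C)c2)oc2cc(-c3ccccc3)cc(O)c12`: 0.35 ug/mL
Compound 3, `Cc1c(C(=O)c2ccc(F)c(F)c2)oc2cc(-c3ccccc3)cc(O)c12`: 0.4 ug/mL

The three compounds share a common core and differ only in the substitution of the aromatic ring attached to the carbonyl. In a functional assay on WI-38 VA13 cells (Homo sapiens) for cytotoxicity (a lower number here means that less compound is needed, a higher number that more compound is needed for the effect), compound 2 gives 0.35 ug/mL. Compound 3 gives 0.4 ug/mL in this assay, and the gap between compound 2 and compound 3 lies within the scatter, so the two cannot be told apart. For compound 1 this assay reports only a limit, > 4 ug/mL, and not a number; compound 1 thus sits at the limit of > 4 ug/mL in this assay, at which 1 of the 3 values shown sits.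

Compound 4, `Cc1c(C(=O)c2cccc(C(F)(F)F)c2)oc2cc(-c3ccccc3)cc(O)c12`, has not yet been measured in this assay. Compared with compound 2 the change is trifluoromethyl in place of isopropoxy on an aromatic carbon. Among the measured compounds shown here, no measured pair shows this change. Since compound 3, which carries fluorine on the same ring, gives 0.4 ug/mL close to compound 2, a step of no more than the usual scatter is expected, in either direction, for the step of a 1.4-fold higher number from compound 2 to compound 4 (0.15 log units; within the scatter). Compound 4 is therefore estimated at 0.5 ug/mL, with a likely range from 0.15 ug/mL to 2 ug/mL.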

Compound 4, half-maximal effective concentration: > 4 ug/mL
Compound 4: no number, only a limit; the forecaster's own chance of this, stated with the estimate: 10%; middle value at least 8.0-fold (0.90 log units) from the limit.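

Replacing isopropoxy with trifluoromethyl on this aromatic carbon, meta to a large group, proves far from neutral in this assay: the change gives an at least 11-fold higher number from compound 2 to compound 4 (1.05 log units; beyond the scatter). From the compounds shown here alone, compound 4 gives > 4 ug/mL, which is a limit of the assay and not a number, so how far the step extends remains unknown. The two groups have the same count of heavy atoms and neither contains a ring, so that count alone does not decide the outcome at this position, although isopropoxy carries a hydrogen-bond acceptor and trifluoromethyl carries none, and the limit now recurs: the limit of > 4 ug/mL in this assay, at which 2 of the 4 values shown sit.

The compounds shown cannot separate the contribution of the oxygen in isopropoxy from that of its branched carbon chain, and a single pair cannot link the step to the difference in hydrogen-bond acceptors. Going by these compounds, whether a methoxy group, an ethoxy group or an amine at this same place would keep a value close to that of compound 2 also remains open, as does whether the step would be the same with a different substituent on the rest of the shared core.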